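Swapping the aryl group on the shared core: what to expect

This account rests on a few compounds, and the source may have more. Where it says the series, first, only, none or still open, it means among the compounds named here.

Of the compounds shown here, two built on a shared core have been measured in an assay on CHO cells for displacement of a labelled ligand from Substance-P receptor (Homo sapiens); a lower number here means a stronger inhibitor, a higher number a weaker inhibitor. Compound 1 `C[C@@H](O[C@H]1CN2C(=O)C=C(c3ccc(NS(C)(=O)=O)cc3)CC2[C@@H]1c1ccc(F)cc1)c1cc(C(F)(F)F)cc(C(F)(F)F)c1` gives 1 nM there. Compound 2 `COc1cc(C2=CC(=O)N3C[C@H](O[C@H](C)c4cc(C(F)(F)F)cc(C(F)(F)F)c4)[C@@H](c4ccc(F)cc4)C3C2)ccn1` gives 1.1 nM in this assay; its number and that of compound 1 lie within the scatter of each other, so neither can be called the stronger binder. For the measured compounds named here, the one step in the set, a 1.1-fold higher number from compound 1 to compound 2 (0.04 log units; within the scatter), exchanged one aromatic group for another on a double-bonded ring carbon of the core and left the number unchanged beyond the scatter.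

Compound 3 `C[C@@H](O[C@H]1CN2C(=O)C=C(c3ccc[n+]([O-])c3)CC2[C@@H]1c1ccc(F)cc1)c1cc(C(F)(F)F)cc(C(F)(F)F)c1` has not yet been measured. It differs from compound 2 by a group of 7 heavy atoms (5 carbon, 1 nitrogen, 1 oxygen; one six-membered aromatic ring with 1 hetero atom) in place of a group of 8 heavy atoms (6 carbon, 1 nitrogen, 1 oxygen; one six-membered aromatic ring with 1 hetero atom), on a double-bonded ring carbon. Going by the values given here, no measured step introduces this entering group, so the step from compound 1 to compound 2 is the only guide, and it shows that the core accepted one exchange of the aromatic group at this point without a shift beyond the scatter. On that basis the number for compound 3 is expected to stay close to that of compound 2, with at most a small rise, as a step of a 1.8-fold higher number from compound 2 to compound 3 (0.26 log units; within the scatter). The estimate for compound 3 in this assay is therefore 2 nM, within a range from 0.5 nM to 8 nM.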

Compound 3, half-maximal inhibitory concentration: 0.15 nM
For compound 3 the middle estimate is 13-fold (1.12 log units) above the measured one; the whole stated range lies above it.
By their numbers in this assay, from the lowest: compound 3; then compounds 1 and 2 (each within the scatter of the next).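

In this assay, for the compounds shown here, the earlier pair showed only that two different aromatic groups on this double-bonded ring carbon gave numbers within the scatter of each other, which could have suggested that the choice of group matters little here. The new steps show otherwise: there is a 7.3-fold lower number from compound 2 to compound 3 (0.87 log units; beyond the scatter), and a 6.7-fold lower number from compound 1 to compound 3 (0.82 log units; beyond the scatter), so the number does respond to the group at this carbon, and the pyridine N-oxide group, the smallest of the three by heavy-atom count, goes with the lowest number of the set. No measurement shown bears on why this group differs from the other two.

The step from compound 2 to compound 3 loses the methoxy group and gains the oxygen on the ring nitrogen in a single exchange, so the compounds shown cannot separate these two changes, and a plain pyridine ring carrying neither would be needed to tell them apart. From the compounds shown here alone, it also remains open whether a different group on this aromatic ring, such as an amine or a carboxylic acid, would keep the number as low.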